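The source may hold more compounds than are shown below. What is called first, only, known or untested is meant among the compounds shown, and "the series" means these compounds.

Of the compounds shown here, two built on one shared core have been tested in a functional assay on COLO 205 cells (Homo sapiens) for inhibition, read by sulforhodamine B assay, tested at 100 uM; a lower number here means less inhibition of growth, a higher number more inhibition of growth at the concentration tested. Compound 1 `COc1cc(C2CC(c3ccc(Br)cc3)=NN2C(C)=O)ccc1OCc1cn(Cc2ccc([N+](=O)[O-])cc2)nn1` carries a 4-bromophenyl group on a carbon with a double bond to nitrogen, and in this assay compound 1 gives 47%. Compound 2 `COc1cc(C2CC(c3cccc4ccccc34)=NN2C(C)=O)ccc1OCc1cn(Cc2ccc([N+](=O)[O-])cc2)nn1` carries a naphthalen-1-yl group at the same place, and in this assay compound 2 gives 72%. Among the compounds with values here, the one measured step, a number 25 percentage points higher from compound 1 to compound 2 (beyond the scatter), is the only guide available. Among the two numbers compound 2 stands highest, with compound 1 the nearest and lower by a margin beyond the scatter.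

Compound 3 `COc1cc(C2CC(c3ccc(Cl)cc3)=NN2C(C)=O)ccc1OCc1cn(Cc2ccc([N+](=O)[O-])cc2)nn1` differs from compound 2 in one place: 4-chlorophenyl in place of naphthalen-1-yl on a carbon with a double bond to nitrogen. The entering 4-chlorophenyl group closely resembles the 4-bromophenyl group of compound 1, one halogen on the ring in place of another, so the change largely runs the measured step backwards. Within the data shown here, a fall of about the same size is expected, estimated as a number 24 percentage points lower from compound 2 to compound 3 (beyond the scatter), because a number 25 percentage points higher from compound 1 to compound 2 (beyond the scatter) is the only measured comparison and points the other way. Compound 3 is therefore expected to land near compound 1, at an estimated 48%, with a likely range from 32% to 64%.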

Compound 3, percent growth inhibition at one concentration: 10%
Estimate against measurement, compound 3: 38 percentage points above; the whole stated range lies above it.
By their numbers in this assay, from the lowest: compound 3; then compound 1; then compound 2.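

Within the data shown here, the position is more sensitive than the single earlier step could show: in this assay, 4-chlorophenyl in place of naphthalen-1-yl gives a number 62 percentage points lower from compound 2 to compound 3 (beyond the scatter) and takes the series to its lowest number so far. The more striking change is the smallest one, since chloro in place of bromo on an aromatic carbon gives a number 37 percentage points lower from compound 1 to compound 3 (beyond the scatter) even though the rest of the structure stays the same. At this carbon with a double bond to nitrogen, then, two groups that look nearly alike on paper can give very different growth inhibition, and no measurement at hand explains the gap.

A plain phenyl, a 4-fluorophenyl or a 4-iodophenyl group at the same place would show whether the halogen swap marks a steady trend or a sharp difference confined to chloro and bromo. A naphthalen-2-yl group would show whether the high number of compound 2 depends on how the second ring is attached, and every comparison here still rests on growth inhibition at a single concentration.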